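The compounds below may be only part of what the source reports. "The series", "measured", "known", "first", "only" and "open" are said of these compounds alone.

Measured compounds:
compound 1, `COc1cc(/C=C/c2ccc(NC(=O)/C=C/c3ccc(C(F)(F)F)cc3)cc2)cc(OC)c1`: 3520 nM
compound 2, `COc1cc(/C=C/c2ccc(NC(=O)/C=C/c3ccc(F)cc3F)cc2)cc(OC)c1`: > 20000 nM

Two analogues share the core of compound 1 and differ only in the aryl group on the double-bonded chain carbon bound to a double-bonded chain carbon. In a functional assay on MDA-MB-231 cells (Homo sapiens) for inhibition, read by MTT assay, with a stated time of 48 h (a higher number here means a weaker inhibitor, a lower number a stronger inhibitor), compound 1 gives 3520 nM. For compound 2 the result in this assay is a limit of the assay rather than a number, > 20000 nM. Among the compounds with values here, the one measured step, an at least 5.6-fold higher number from compound 1 to compound 2 (0.75 log units; beyond the scatter), is therefore only a lower bound, since compound 2 sits at the limit of > 20000 nM in this assay, at which 1 of the 2 values shown sits.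

Compound 3, `COc1cc(/C=C/c2ccc(NC(=O)/C=C/c3ccc(Cl)cc3)cc2)cc(OC)c1`, is the next member to be measured. It differs from compound 2 by 4-chlorophenyl in place of 2,4-difluorophenyl on a double-bonded chain carbon bound to a double-bonded chain carbon. Within the data shown here, only the step from compound 1 to compound 2 bears on this change; it shows that moving from 4-(trifluoromethyl)phenyl to 2,4-difluorophenyl weakened inhibition by at least a modest amount. Compound 3 reverts to a singly substituted aryl group, as in compound 1, so the expectation is a return toward the value of compound 1 rather than the limit of compound 2. The expected step is an at least 4.0-fold lower number from compound 2 to compound 3 (0.60 log units; beyond the scatter), a lower number in this assay. Compound 3 is expected to give about 5000 nM, with a range from 1500 nM to 20000 nM.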

Compound 3, half-maximal inhibitory concentration: 14100 nM
Beside the measured number, compound 3's estimate is 2.8-fold (0.45 log units) below it, and the stated range covers the measured number.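

In this assay, within the data shown here, chloro in place of trifluoromethyl on an aromatic carbon gives a 4.0-fold higher number from compound 1 to compound 3 (0.60 log units; beyond the scatter), the first step with a number at both ends, and it shows that the value of compound 1 does not carry over to every singly substituted aryl group. The change from the 2,4-difluorophenyl group to the 4-chlorophenyl group gives an at least 1.4-fold lower number from compound 2 to compound 3 (0.15 log units; that floor lies within the scatter), so the floor of this step does not by itself separate the two groups. Compound 2 carries a limit of the assay and not a number: the limit of > 20000 nM in this assay, at which 1 of the 3 values shown sits.

Open, as far as these compounds go, is how far compound 2 and compound 3 truly stand apart, and with it whether the 4-chlorophenyl group gives any real gain over the 2,4-difluorophenyl group. Also open, from the compounds shown here alone, is how a methoxy group, a nitrile or a dimethylamino group would read in this assay on the aromatic carbon that carries trifluoromethyl in compound 1 and chloro in compound 3, and so whether trifluoromethyl stands out among substituents there or only against chloro.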